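A Pyrazole Replaces the Thiophene on the Amide Arm

The source may report more compounds than this note shows. Statements on the series, on what has been measured and on what is new or still open speak of the compounds shown alone.

Of the compounds shown here, three have so far been tested in an assay on HEK293 cells for agonist activity at transient receptor potential cation channel subfamily M member 8 (Homo sapiens), read by fluorescence and calcium flux, with a stated time of 15 min; a lower number here means that less compound is needed, a higher number that more compound is needed for the effect. Compound 1 `CCN(Cc1cccs1)C(=O)/C=C/c1ccc(C)cc1` gives 2 nM, compound 2 `CCN(Cc1cccs1)C(=O)COc1ccc(F)cc1` gives 422 nM, and compound 3 `CCN(Cc1ccsc1)C(=O)COc1ccc(C)cc1` gives 88 nM. Of these three numbers compound 3 holds the second highest: compound 2 sits above it and compound 1 far below it, both gaps beyond the usual scatter. Compound 4 `CCN(Cc1cc[nH]n1)C(=O)COc1ccc(C)cc1` is not yet measured. It differs from compound 3 in one place: 1H-pyrazol-3-yl in place of thiophen-3-yl on a saturated chain carbon bound to an amide-type nitrogen. For the measured compounds named here, no measured pair shows this kind of change, so its size is uncertain; in this assay a moderate rise in the number is expected, probably beyond the scatter. The expected step is a 3.4-fold higher number from compound 3 to compound 4 (0.53 log units; beyond the scatter). Compound 4 is estimated at 300 nM, within a range from 60 nM to 1500 nM.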

Compound 4, half-maximal effective concentration: "not active" (no number reported)
No number was reported for compound 4; there is nothing to compare the estimate with.
By their numbers in this assay, from the lowest: compound 1; then compound 3; then compound 2.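

For the compounds shown here, compound 4 is reported as not active, with no number, so no step from compound 3 to compound 4 can be read. No evidence at hand bears on this result. The compounds shown leave open how large the change from thiophen-3-yl to 1H-pyrazol-3-yl is.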